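This account rests on a few compounds, and the source may have more. Where it says the series, first, only, none or still open, it means among the compounds named here.

Four compounds built on a shared core are compared here. Compound 1 `COc1ccc(CCOC(=O)c2oc3cc(-c4ccccc4)cc(O)c3c2C)cc1` joins the core to its side chain through an ester, while compound 2 `COCc1ccccc1C(=O)c1oc2cc(-c3ccccc3)cc(O)c2c1C` and compound 3 `Cc1c(C(=O)c2cccc(C(F)(F)F)c2)oc2cc(-c3ccccc3)cc(O)c12` do so through a carbonyl carbon bearing an aromatic ring. In a functional assay on WI-38 VA13 cells (Homo sapiens) for cytotoxicity (a lower number here means that less compound is needed, a higher number that more compound is needed for the effect), compound 1 gives 0.02 ug/mL. In this assay compound 2 gives 0.1 ug/mL, the highest of the two numbers recorded, and the gap down to compound 1 lies beyond the usual scatter. For compound 3, this assay returns only a limit, > 4 ug/mL, not a number; that reading is the limit of > 4 ug/mL in this assay, at which 1 of the 3 values shown sits.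

Compound 4 `Cc1c(C(=O)CCc2ccccc2)oc2cc(-c3ccccc3)cc(O)c12` has not yet been measured. It differs from compound 2 in one place (phenethyl in place of 2-(methoxymethyl)phenyl on a carbonyl carbon). Among the measured compounds shown here, no measured pair in this set differs in a single place, so no recorded step tells how large such a change tends to be. The author expects the step of a 1.4-fold lower number from compound 2 to compound 4 (0.15 log units; within the scatter) to be modest, leaning toward a lower number for compound 4 but not clearly beyond the scatter, with some chance that this assay again returns a limit. Compound 4 is accordingly estimated at 0.07 ug/mL, within a range from 0.015 ug/mL to 0.4 ug/mL.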

Compound 4, half-maximal effective concentration: > 4 ug/mL
Compound 4: a limit, no number (the forecaster's own chance of this, stated with the estimate: 10%); at least 57-fold (1.75 log units) between middle value and limit.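

Among the compounds shown here, the step, an at least 40-fold higher number from compound 2 to compound 4 (1.60 log units; beyond the scatter), is the first single-place change available in this set, and it shows that in this assay the read-out depends strongly on the group at this carbonyl carbon, whose other neighbour is aromatic carbon. Both the leaving and the entering group carry one six-membered aromatic ring of carbon only, so the presence of such a ring alone does not hold the read-out where compound 2 stands, at 0.1 ug/mL. Compound 4 gives only a limit, > 4 ug/mL, not a number, and this reading is shared within the set: the limit of > 4 ug/mL in this assay, at which 2 of the 4 values shown sit.

The change removes the oxygen of the 2-(methoxymethyl)phenyl group and also replaces that aryl group with phenethyl, and the compounds shown do not separate these two differences, which an unsubstituted phenyl or a benzyl on the same carbonyl carbon could begin to do. Also open, as far as these compounds go, is whether a longer chain, or a chain carrying an amine, would return a number in this assay or another limit.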